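Benzimidazole series: aryl swap at the distal ring

The source may report more compounds than this note shows. Statements on the series, on what has been measured and on what is new or still open speak of the compounds shown alone.

Measured so far:
compound 1 `CN1CCN(CCCN(c2nc3cc(F)c(F)cc3[nH]2)[C@@H]2CC[C@]3(c4cccc(CN5CCC[C@H]5CO)c4)C[C@@H]3C2)CC1` with 3000 nM
compound 2 `Fc1cc2[nH]c(C(=C3CCN(CC4CC4)CC3)c3ccc(-c4cncnc4)cc3)nc2cc1C(F)(F)F` with 95 nM

In an assay on CHO cells for antagonist activity at melanin-concentrating hormone receptor 1 (Homo sapiens), read by luminescence and calcium flux, with a stated time of 10 min (on this read-out lower numbers stand for stronger inhibition and higher numbers for weaker inhibition), compound 2 gives 95 nM, the lowest number of the two, and compound 1 sits far higher, beyond the scatter. Compound 3 `N#Cc1cccc(-c2ccc(C(=C3CCN(CC4CC4)CC3)c3nc4cc(C(F)(F)F)c(F)cc4[nH]3)cc2)c1` is not yet measured; it differs from compound 2 by 3-cyanophenyl in place of pyrimidin-5-yl on an aromatic carbon. Among the measured compounds shown here, no measured pair in this set shows such a change, so no step size can be drawn from the data. The step from compound 2 to compound 3 is expected to be small, a 1.2-fold lower number from compound 2 to compound 3 (0.07 log units; within the scatter), not clearly beyond the scatter in either direction. Compound 3 is therefore estimated at 80 nM, within 25 nM to 300 nM.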

Compound 3, half-maximal inhibitory concentration: 3.5 nM
Compound 3: the middle estimate sits 23-fold (1.36 log units) above what was measured; the whole stated range lies above it.
By their numbers in this assay, from the lowest: compound 3; then compound 2; then compound 1.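

The carbon-only aromatic ring position, para to a large group, responds strongly to the identity of its aryl substituent: in this assay, 3-cyanophenyl in place of pyrimidin-5-yl gives a 27-fold lower number from compound 2 to compound 3 (1.43 log units; beyond the scatter), a large step beyond the scatter. Among the compounds shown here, this is the first one-place step, and it shows that this position is not indifferent to the swap. Nothing available accounts for the size of this step.

Going by these compounds, the change alters the ring atoms and adds the nitrile together, so the share of each remains open. Plain phenyl, or a carboxylic acid in place of the nitrile, would help separate them.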